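Methyl on the Sulfonyl Ring, Tested on a Trichloro Core

A few compounds are considered here, and "the series" means these few. Any claim that something is new, unique, unknown or untested is made for them only; others in the source may bear on it.

Measured so far in an assay on MDA-MB-231 cells for binding affinity to C-X-C chemokine receptor type 4 (Homo sapiens), read by immunofluorescence and microscopy, with stated times of 10 min and 30 min; on this read-out lower numbers stand for an effect already at smaller amounts and higher numbers for an effect only at larger amounts of compound:
Compound 1, `Cc1ccc(S(=O)(=O)NCc2ccc(CNC(=O)c3ccc(F)cc3)cc2)cc1`, gives 1 nM.
Compound 2, `O=C(NCc1ccc(CNS(=O)(=O)c2ccccc2)cc1)c1ccc(F)cc1`, gives 100 nM.
Compound 3, `O=C(NCc1ccc(CNS(=O)(=O)c2ccccc2)cc1)c1c(Cl)cc(Cl)cc1Cl`, gives 10 nM.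

Compound 4, `Cc1ccc(S(=O)(=O)NCc2ccc(CNC(=O)c3c(Cl)cc(Cl)cc3Cl)cc2)cc1`, has not yet been measured in this assay. It differs from compound 3 in one place: methyl in place of hydrogen on an aromatic carbon. The same change separates compound 2 from compound 1: methyl in place of hydrogen on an aromatic carbon. The place of the change is described in the same words in both pairs, so it counts as the same change. In this assay that change made a 100-fold lower number from compound 2 to compound 1 (2.00 log units; beyond the scatter). The two cores on which it is made are not identical: 2,4,6-trichlorophenyl in place of 4-fluorophenyl on a carbonyl carbon, and that difference by itself made a 10-fold lower number from compound 2 to compound 3 (1.00 log units; beyond the scatter).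

For compound 4, a step in the same direction is expected, but somewhat smaller than the earlier one, because a step as large as a 100-fold lower number from compound 2 to compound 1 (2.00 log units; beyond the scatter) has been seen only once here and may not repeat in full on another core. The expected step is therefore a 20-fold lower number from compound 3 to compound 4 (1.30 log units; beyond the scatter). On that basis compound 4 is estimated at 0.5 nM, with a likely range from 0.1 nM to 3 nM.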

Compound 4, effective concentration (reported as EC, without a stated level of effect): 10 nM
For compound 4 the middle estimate is 20-fold (1.30 log units) below the measured one; the whole stated range lies below it.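

In this assay, the methyl of the 4-methylphenyl group gave no change at the digits printed from compound 3 to compound 4 (within the scatter) on the trichloro core, so the large gain seen on the 4-fluorophenyl core did not carry over: the same change on two cores in this assay, a 100-fold lower number (2.00 log units; beyond the scatter) from compound 2 to compound 1 and no change at the digits printed (within the scatter) from compound 3 to compound 4, 100-fold (2.00 log units) apart, beyond the scatter of two such steps. Seen from the other side, 2,4,6-trichlorophenyl in place of 4-fluorophenyl gave a 10-fold lower number from compound 2 to compound 3 (1.00 log units; beyond the scatter) without the methyl but a 10-fold higher number from compound 1 to compound 4 (1.00 log units; beyond the scatter) with it, so the two changes do not simply add up in these compounds: the same change on two cores in this assay, a 10-fold lower number (1.00 log units; beyond the scatter) from compound 2 to compound 3 and a 10-fold higher number (1.00 log units; beyond the scatter) from compound 1 to compound 4, 100-fold (2.00 log units) apart, beyond the scatter of two such steps. This shows that, among these four compounds, the size of the methyl step depends on the core, but it does not show why, and a single comparison cannot predict the step on any further core.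

The compounds shown leave open whether an ethyl group, a methoxy group or an amine in place of the methyl would follow the same pattern on either core. They also leave open how the methyl step would turn out with a third group on the carbonyl carbon, such as cyclohexyl.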